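The source may hold more compounds than are shown below. What is called first, only, known or untested is meant among the compounds shown, and "the series" means these compounds.

Working notes on the benzoxazole-free description: the shared core of compound 1 `Cc1ccc(S(=O)(=O)Nc2ccc3oc(-c4ccccc4)nc3c2)cc1` carries a sulfonamide, and the series varies the ring on the sulfonyl sulfur. In an assay on isolated protein for inhibition of malate dehydrogenase, mitochondrial (Sus scrofa), with stated times of 45 min and 30 min (a lower number here means a stronger inhibitor, a higher number a weaker inhibitor), compound 1 gives > 63000 nM, which is a limit of the assay and not a number. Compound 2 `O=S(=O)(Nc1ccc2oc(-c3ccccc3)nc2c1)c1ccc(Cl)c(C(F)(F)F)c1` in this assay gives > 63000 nM, again a limit. Both measured values sit together (the limit of > 63000 nM in this assay, at which 2 of the 2 values shown sit). Compound 3 `O=S(=O)(Nc1ccc2oc(-c3ccccc3)nc2c1)c1cccc(Cl)c1` differs from compound 1 by 3-chlorophenyl in place of 4-methylphenyl on a sulfonyl sulfur. For the measured compounds named here, no step between measured compounds is available to size this change, and the only anchor is compound 1 at its limit. The step that the limit leaves unreadable from compound 1 to compound 3 is expected to stay within the scatter. Compound 3 is expected to give 80000 nM, between 25000 nM and 250000 nM, most probably reported only as a limit.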

Compound 3, half-maximal inhibitory concentration: > 63000 nM
Compound 3: a limit, no number (the forecaster's own chance of this, stated with the estimate: 85%); the middle value does not contradict the limit.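

For the compounds shown here, compound 1 and compound 3 both stand as limits and not numbers in this assay and no step between them can be read. The compounds shown leave open which ring on the sulfonyl sulfur, if any, gives a measurable inhibition.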